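This account rests on a few compounds, and the source may have more. Where it says the series, first, only, none or still open, it means among the compounds named here.

Measured so far in a functional assay on PBMC cells (Homo sapiens) for inhibition, read by HTRF, with stated times of 15 min and 24 h; a lower number here means a stronger inhibitor, a higher number a weaker inhibitor:
Compound 1 `O=C(Nc1ccc2c(c1)B(O)OC2)c1ccccc1Cl`: > 100000 nM
Compound 2 `O=C(Nc1ccc2c(c1)B(O)OC2)c1c(F)cccc1C(F)(F)F`: 180 nM

Going by the values given here, compound 2, at 180 nM, holds the only true number in this small set, so it can be placed against no other measured potency. The sole other result is a limit and not a number, and it belongs to compound 1.

Compound 3 `O=C(Nc1ccc2c(c1)B(O)OC2)c1c(F)cccc1Cl` has not yet been measured. It carries chloro in place of trifluoromethyl on an aromatic carbon, (chloro in place of trifluoromethyl on an aromatic carbon), and the rest of compound 2 is unchanged.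

Among the compounds with values here, no measured pair shows what this exchange does on its own, so any forecast is uncertain. Compound 1 reads > 100000 nM, which warns that activity in this assay cannot be taken for granted on the shared core. A moderate weakening is therefore expected, probably beyond the usual scatter, with a wide margin on either side.

The estimated change is a 2.8-fold higher number from compound 2 to compound 3 (0.44 log units; beyond the scatter). For compound 3 the expected value is 500 nM, with an estimated range of 80 nM to 5000 nM.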

Compound 3, half-maximal inhibitory concentration: 3100 nM
Compound 3: middle estimate off by 6.2-fold (0.79 log units), on the low side, within the range that was stated.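

The exchange of trifluoromethyl for chloro on this aromatic carbon now has a measured size in this assay: a 17-fold higher number from compound 2 to compound 3 (1.24 log units; beyond the scatter), so the group at this position matters a great deal, and of the two groups compared, trifluoromethyl gives the lower number. With chloro held in place, fluoro in place of hydrogen on an aromatic carbon gives an at least 32-fold lower number from compound 1 to compound 3 (1.50 log units; beyond the scatter), which shows that this second position also has a large say in the result and that the shared core can give a measurable potency with chloro present. The reading for compound 1 is a limit and not a number: the limit of > 100000 nM in this assay, at which 1 of the 3 values shown sits.

From the compounds shown here alone, only chloro and trifluoromethyl can be compared at this position, so it remains open whether a methoxy group, a nitrile or an amine on the same carbon would read nearer to compound 2 or to compound 3. It is also open whether fluoro in place of hydrogen would have a step of similar size with trifluoromethyl in place of chloro, since the compounds shown give that step only with chloro present.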